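The compounds below may be only part of what the source reports. "The series", "measured", "known", "first", "only" and "open" are said of these compounds alone.

Working notes on the series. The shared core is that of compound 1 `O=C1NCCC12CCN(c1c(Cl)cncc1-c1cc[nH]c1)CC2`, which in a functional assay on MV4-11 cells (Homo sapiens) for inhibition, read by resazurin assay, with a stated time of 72 h (on this read-out lower numbers stand for stronger inhibition of growth and higher numbers for weaker inhibition of growth), gives 1050 nM. Of the two numbers shown, compound 1 stands highest; nearest is compound 2 `O=Cc1ccc(-c2cncc(Cl)c2N2CCC3(CCNC3=O)CC2)s1`, which in this assay gives 750 nM, the gap being a 1.4-fold lower number from compound 1 to compound 2 (0.15 log units; within the scatter). Compound 3 `CC(=O)c1sccc1-c1cncc(Cl)c1N1CCC2(CCNC2=O)CC1` yields only a limit of this assay, > 100000 nM. The step of an at least 95-fold higher number from compound 1 to compound 3 (1.97 log units; beyond the scatter) is large, as is an at least 130-fold higher number from compound 2 to compound 3 (2.12 log units; beyond the scatter); both rest on (the limit of > 100000 nM in this assay, at which 1 of the 3 values shown sits).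

Compound 4 `O=C1NCCC12CCN(c1c(Cl)cncc1-c1cnn(C(F)F)c1)CC2` awaits measurement. It differs from compound 1 by 1-(difluoromethyl)-1H-pyrazol-4-yl in place of 1H-pyrrol-3-yl on an aromatic carbon. Two measured steps replace the same five-membered ring at the same carbon: a 1.4-fold lower number from compound 1 to compound 2 (0.15 log units; within the scatter) stays within the scatter, while an at least 95-fold higher number from compound 1 to compound 3 (1.97 log units; beyond the scatter) is a large loss. The change to compound 4 keeps a five-membered aromatic ring on that carbon and resembles the first of these more than the second, so no step beyond the scatter, or a small weakening at most, is expected in this assay. Compound 4 is estimated at 1500 nM, within 400 nM to 6000 nM. The expected step is a 1.4-fold higher number from compound 1 to compound 4 (0.15 log units; within the scatter).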

Compound 4, concentration for 50% growth inhibition: 6140 nM
For compound 4 the middle estimate is 4.1-fold (0.61 log units) below the measured one, and the stated range ends below it.
By their numbers in this assay, from the lowest: compounds 2 and 1 (each within the scatter of the next); then compound 4. At a limit, above all of these: compound 3.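

In this assay the step of a 5.8-fold higher number from compound 1 to compound 4 (0.77 log units; beyond the scatter) shows that a five-membered aromatic ring on this carbon does not by itself hold the level of compound 1, and an 8.2-fold higher number from compound 2 to compound 4 (0.91 log units; beyond the scatter) shows the same against the other compound with a comparable number. This position therefore gives an intermediate outcome, not only the two seen earlier, a step within the scatter or a large loss. The step of an at least 16-fold lower number from compound 3 to compound 4 (1.21 log units; beyond the scatter) is read against a limit of the assay, not a number: the limit of > 100000 nM in this assay, at which 1 of the 4 values shown sits.

As far as these compounds go, the change alters the ring and its substituent together, so the share of the pyrazole ring and that of the difluoromethyl group remain open. A 1H-pyrazol-4-yl group or a 1-methyl-1H-pyrazol-4-yl group on the same carbon would separate the two.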